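This account rests on a few compounds, and the source may have more. Where it says the series, first, only, none or still open, it means among the compounds named here.

Measured compounds:
- compound 1, `COc1ccc(CNc2nc(N3CCN(C4CCCC4)CC3)c3ncn(CCCN4CCCC4)c3n2)cc1`: 240 nM
- compound 3, `Fc1ccc(CNc2nc(N3CCN(C4CCCC4)CC3)c3ncn(CCCN4CCCC4)c3n2)cc1`: 100 nM
- compound 2, `CCN1CCN(CCCn2cnc3c(N4CCN(C(=O)C5CCCC5)CC4)nc(NCc4ccc(OC)cc4)nc32)CC1`: a limit only, > 30000 nM

In an assay on HEK293 cells for antagonist activity at Toll-like receptor 9 (Homo sapiens), read by spectrophotometry (on this read-out higher numbers stand for weaker inhibition and lower numbers for stronger inhibition), compound 1 gives 240 nM, while compound 3 gives 100 nM. The change between them is fluoro in place of methoxy on an aromatic carbon, and it produces a 2.4-fold lower number from compound 1 to compound 3 (0.38 log units; beyond the scatter). Compound 2 reaches only a limit in this assay, > 30000 nM; this value sits at the limit of > 30000 nM in this assay, at which 1 of the 3 values shown sits. How the core of compound 2 differs from the core of compound 1 is not broken down here.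

Compound 4, `CCN1CCN(CCCn2cnc3c(N4CCN(C(=O)C5CCCC5)CC4)nc(NCc4ccc(F)cc4)nc32)CC1`, is not yet measured in this assay. It differs from compound 2 by fluoro in place of methoxy on an aromatic carbon, the same change as from compound 1 to compound 3. For this step an expected size of a number no higher from compound 2 to compound 4 (the limit leaves the size open) is taken, resting on a 2.4-fold lower number from compound 1 to compound 3 (0.38 log units; beyond the scatter). Since compound 2 gives only a limit, compound 4 is expected near 30000 nM, estimated between 8000 nM and 100000 nM, most likely again reported as a limit.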

Compound 4, half-maximal inhibitory concentration: > 30000 nM
Compound 4 gave a limit, no number; the forecaster's own chance of this, stated with the estimate: 70%; the middle value lies on the limit itself.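

Compound 2 and compound 4 both give only limits, so no step can be read between them: the limit of > 30000 nM in this assay, at which 2 of the 4 values shown sit.

From the compounds shown here alone, whether fluoro in place of methoxy changes inhibition on the core of compound 2 remains open.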